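From cyano to methoxy on compound 2

A few compounds are considered here, and "the series" means these few. Any claim that something is new, unique, unknown or untested is made for them only; others in the source may bear on it.

In a functional assay on NCI-N87 cells (Homo sapiens) for antiproliferative activity, read by CCK-8 assay, with a stated time of 72 h (a lower number here means a stronger inhibitor, a higher number a weaker inhibitor), the measured compounds give these values:
- Compound 1 `Cc1cc(Nc2cc(N3CCN(C)CC3)nc(Nc3cccc(Cl)c3)n2)n[nH]1`: 1770 nM
- Compound 2 `Cc1cc(Nc2cc(N3CCN(C)CC3)nc(Nc3ccc(C#N)cc3)n2)n[nH]1`: 5780 nM

Compound 2 at 5780 nM has the higher number of the two and is the weaker inhibitor. Compound 3 `COc1ccc(Nc2nc(Nc3cc(C)[nH]n3)cc(N3CCN(C)CC3)n2)cc1` differs from it by methoxy in place of cyano on an aromatic carbon and keeps the shared core. Among the measured compounds shown here, one measured step bears on this: a 3.3-fold higher number from compound 1 to compound 2 (0.51 log units; beyond the scatter) with 4-cyanophenyl in place of 3-chlorophenyl. That single step is thin evidence, but it came with cyano arriving, and cyano now leaves. Expected in this assay is a modest move toward a lower number, estimated as a 2.3-fold lower number from compound 2 to compound 3 (0.36 log units; beyond the scatter) here. For compound 3 the estimated value is 2500 nM with 900 nM to 7500 nM as the expected range.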

Compound 3, half-maximal inhibitory concentration: 18900 nM
Compound 3: middle estimate off by 7.6-fold (0.88 log units), on the low side, outside the stated range (above it).
By their numbers in this assay, from the lowest: compound 1; then compound 2; then compound 3.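

In this assay, the change gives a 3.3-fold higher number from compound 2 to compound 3 (0.51 log units; beyond the scatter), so removing cyano from this aromatic carbon did not bring the number down; methoxy reads higher still. Set against the 3-chlorophenyl group, 4-methoxyphenyl gives an 11-fold higher number from compound 1 to compound 3 (1.03 log units; beyond the scatter), a larger step than the one seen for 4-cyanophenyl. No measurement available here accounts for this order. From the compounds shown here alone, how an amine or a carboxylic acid in place of methoxy would read remains open, and so does the reading of an unsubstituted phenyl.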